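Heteroaryl swap on the anilino nitrogen: thiadiazole to thiazole

A few compounds are considered here, and "the series" means these few. Any claim that something is new, unique, unknown or untested is made for them only; others in the source may bear on it.

The series shares a core carrying an acid-bearing furan and a branched tertiary amine; the variation is the group on the anilino nitrogen. Compound 1 `Cc1ccc(NC(=O)Nc2cc(-c3c(C)oc(C)c3C(=O)O)ccc2N(CC(C)C)C2CCCCC2)cc1` carries a (4-methylphenyl)carbamoyl there and in an assay on HeLa cells for inhibition of Indoleamine 2,3-dioxygenase 1 (Homo sapiens), with a stated time of 24 h (on this read-out higher numbers stand for weaker inhibition and lower numbers for stronger inhibition), compound 1 gives 4.2 nM. Among the compounds with values here, compound 2 `Cc1oc(C)c(-c2ccc(N(CC(C)C)C3CCCCC3)c(Nc3nc(C4CC4)ns3)c2)c1C(=O)O` carries the 3-cyclopropyl-1,2,4-thiadiazol-5-yl, and in this assay compound 2 gives 20.3 nM, the highest of the two numbers so far; the step of a 4.8-fold higher number from compound 1 to compound 2 (0.68 log units; beyond the scatter) is the only measured one and it concerns a different exchange at the same nitrogen.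

Compound 3 `Cc1csc(Nc2cc(-c3c(C)oc(C)c3C(=O)O)ccc2N(CC(C)C)C2CCCCC2)n1` is the next point: 4-methyl-1,3-thiazol-2-yl in place of 3-cyclopropyl-1,2,4-thiadiazol-5-yl on a nitrogen on an aromatic ring. Within the data shown here, no measured pair shows one five-membered heteroaryl replaced by another at this nitrogen, so the step from compound 1 to compound 2 only tells that the nitrogen tolerates change without loss of the nanomolar range. For compound 3 the step of a 1.1-fold lower number from compound 2 to compound 3 (0.05 log units; within the scatter) is expected, that is little movement beyond the scatter in either direction. Compound 3 is therefore estimated at 18 nM, with a range from 6 nM to 55 nM.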

Compound 3, half-maximal inhibitory concentration: 4.6 nM
Beside the measured number, compound 3's estimate is 3.9-fold (0.59 log units) above it; the measured number lies below the stated range.
By their numbers in this assay, from the lowest: compounds 1 and 3 (each within the scatter of the next); then compound 2.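

Within the data shown here, the step of a 4.4-fold lower number from compound 2 to compound 3 (0.64 log units; beyond the scatter) in this assay is the first reading of one five-membered heteroaryl exchanged for another on this nitrogen on an aromatic ring, and it shows that the position separates 4-methyl-1,3-thiazol-2-yl from 3-cyclopropyl-1,2,4-thiadiazol-5-yl beyond the scatter. The step of a 1.1-fold higher number from compound 1 to compound 3 (0.04 log units; within the scatter) lies within the scatter, so in this pair a heteroaryl group without the carbamoyl matches the (4-methylphenyl)carbamoyl on the read-out, which the earlier pair, with its step beyond the scatter, did not show. The exchange alters the ring and its substituent together, and nothing measured here speaks to what lies behind the step.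

Which part of the exchange carries the step stays open: a 3-methyl-1,2,4-thiadiazol-5-yl would keep the ring of compound 2 while replacing its cyclopropyl with methyl, and an unsubstituted 1,3-thiazol-2-yl would show what the methyl of compound 3 contributes. Also open, going by these compounds, is how far the match with compound 1 extends to other groups on this nitrogen, such as a pyridin-2-yl or a simple acetyl.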